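Cytotoxicity of a tertiary amine and its ester replacement

A few compounds are considered here, and "the series" means these few. Any claim that something is new, unique, unknown or untested is made for them only; others in the source may bear on it.

This account follows two compounds of a shared core and a third built on it. Compound 1 `CN(C)c1ccc(NCc2cncn2Cc2ccc(-c3ccccc3)cc2)cc1-c1ccccc1` was tested in a toxicity assay on NIH3T3 cells (Mus musculus) for cytotoxicity, read by resazurin assay; a higher number here means that more compound is needed for the effect, a lower number that less compound is needed. In this assay compound 1 reaches only the limit of the measurement, > 1000 nM. Compound 2 `Nc1cc(-c2ccccc2)ccc1Cn1cncc1CNc1ccc(Cl)c(-c2ccccc2)c1` was tested in the same way. In this assay compound 2 likewise sits at the limit, > 1000 nM. Both results therefore stand at the limit of > 1000 nM in this assay, at which 2 of the 2 values shown sit, so compound 1 stands at the edge of what the measurement reports, with no number of its own.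

Compound 3 `CC(C)OC(=O)c1ccc(NCc2cncn2Cc2ccc(-c3ccccc3)cc2)cc1-c1ccccc1` differs from compound 1 in one place: isopropoxycarbonyl in place of dimethylamino on an aromatic carbon. Among the compounds with values here, no measured step between compounds is available here, so the expectation for this change rests on the two limits alone. The author expects no shift beyond the usual scatter, with the step from compound 1 to compound 3 estimated at a step that the limit leaves unreadable from compound 1 to compound 3. For compound 3 the estimated value in this assay is 3000 nM, within a range of 1000 nM to 30000 nM, most likely again reported only as a limit.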

Compound 3, half-maximal effective concentration: > 10000 nM
Compound 3 gave a limit, no number; the forecaster's own chance of this, stated with the estimate: 80%; at least 3.3-fold (0.52 log units) between middle value and limit.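

Compound 1 and compound 3 each gave only a limit, and the step between them cannot be read. The compounds shown leave open at what concentration any of them becomes cytotoxic, and whether isopropoxycarbonyl in place of dimethylamino changes that concentration at all.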